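The compounds below may be only part of what the source reports. "The series", "measured", "known", "first", "only" and "open" are said of these compounds alone.

The measured compounds are these. Compound 1, `NC(=O)c1c(NC(=O)c2ccccc2F)sc2c1CCN(Cc1c(Cl)cccc1Cl)C2`, gives 7430 nM in a functional assay on MKN-74 cells (Homo sapiens) for antiproliferative activity, with a stated time of 24 h; on this read-out higher numbers stand for weaker inhibition and lower numbers for stronger inhibition. Compound 2, `NC(=O)c1c(NC(=O)c2ccccc2F)sc2c1CCN(C(=S)Nc1ccccc1Cl)C2`, gives 11100 nM in this assay. Compound 3, `NC(=O)c1c(NC(=O)c2ccccc2F)sc2c1CCN(C(=O)Nc1ccccc1Cl)C2`, gives 49600 nM in this assay.

Among these three numbers compound 2 holds the second highest. Its nearest neighbour is compound 1, reached by a 1.5-fold higher number from compound 1 to compound 2 (0.17 log units; within the scatter), and its furthest is compound 3, reached by a 4.5-fold higher number from compound 2 to compound 3 (0.65 log units; beyond the scatter). The third step, a 6.7-fold higher number from compound 1 to compound 3 (0.82 log units; beyond the scatter), likewise concerns only the group on the amine nitrogen in a ring.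

Compound 4, `NC(=O)c1c(NC(=O)c2ccccc2I)sc2c1CCN(C(=S)Nc1ccccc1Cl)C2`, has not been measured in this assay. It differs from compound 2 by iodo in place of fluoro on an aromatic carbon, on an aromatic carbon of a six-membered aromatic ring of carbon only, ortho to a large group. None of the three measured steps touches this position; all of them exchange the group on the amine nitrogen in a ring and leave the fluoro in place. Within the data shown here, there is therefore no measured step that bears directly on the change from compound 2 to compound 4, and the expectation can only rest on the value of compound 2 itself.

On that basis compound 4 is expected to show no step beyond the scatter, a 1.1-fold lower number from compound 2 to compound 4 (0.05 log units; within the scatter), in this assay. The estimate for compound 4 is 10000 nM, with a range from 3000 nM to 40000 nM.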

Compound 4, half-maximal inhibitory concentration: 17500 nM
For compound 4 the middle estimate is 1.8-fold (0.24 log units) below the measured one; the measured number falls inside the stated range.
By their numbers in this assay, from the lowest: compounds 1, 2 and 4 (each within the scatter of the next, the first and the last beyond it); then compound 3.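

Among these compounds, the first measured change at this position, iodo in place of fluoro on an aromatic carbon ortho to a large group, gives in this assay a step of a 1.6-fold higher number from compound 2 to compound 4 (0.20 log units; within the scatter), so compound 2 and compound 4 cannot be told apart on this read-out. Among the compounds shown here, the earlier compounds showed only that the group on the amine nitrogen in a ring can shift the number beyond the scatter, as in a 4.5-fold higher number from compound 2 to compound 3 (0.65 log units; beyond the scatter), whereas this exchange of one single heavy atom for another, at a different place on the molecule, does not. The data shown offer no measurement that could account for this result.

The compounds shown leave open whether a group of another kind on this aromatic carbon, such as an amine, a methoxy group or a carboxylic acid, would give a step beyond the scatter in this assay. They also leave open whether iodo in place of fluoro would give a similar step with the other groups on the amine nitrogen, 2,6-dichlorobenzyl in compound 1 and (2-chlorophenyl)carbamoyl in compound 3.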